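The compounds below may be only part of what the source reports. "The series", "measured", "known", "first", "only" and "open" are said of these compounds alone.

Compounds measured in a functional assay on PC-3 cells (Homo sapiens) for antiproliferative activity, read by MTT assay, with a stated time of 24 h; on this read-out lower numbers stand for stronger inhibition and higher numbers for weaker inhibition:
- compound 1 `CCn1c(C(=O)NCCN)ccc1C(CC)(CC)c1ccc(OCS(=O)(=O)c2ccccc2)c(C)c1`: 6890 nM
- compound 2 `CCn1c(C(=O)N[C@H](C)CO)ccc1C(CC)(CC)c1ccc(OCS(=O)(=O)c2ccccc2)c(C)c1`: 7790 nM
- compound 3 `CCn1c(C(=O)N[C@@H](C)C(=O)O)ccc1C(CC)(CC)c1ccc(OCS(=O)(=O)c2ccccc2)c(C)c1`: 16800 nM

Compound 2 sits second highest of the three numbers in this assay; its nearest neighbour is compound 1 with a 1.1-fold higher number from compound 1 to compound 2 (0.05 log units; within the scatter), its furthest compound 3 with a 2.2-fold higher number from compound 2 to compound 3 (0.33 log units; beyond the scatter). All three share the same core and differ only in the group on the amide-type nitrogen.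

Compound 4 `CCn1c(C(=O)N[C@H](C)C(=O)O)ccc1C(CC)(CC)c1ccc(OCS(=O)(=O)c2ccccc2)c(C)c1` is the next member. The change from compound 2 is carboxy in place of hydroxymethyl on a saturated chain carbon bound to an amide-type nitrogen and a saturated chain carbon.

Among the compounds with values here, the step that bears most directly on this change is the one from compound 2 to compound 3, where a 1-carboxyethyl group likewise enters in place of 1-(hydroxymethyl)ethyl: a 2.2-fold higher number from compound 2 to compound 3 (0.33 log units; beyond the scatter). The related step of a 2.4-fold higher number from compound 1 to compound 3 (0.39 log units; beyond the scatter) points the same way, from a 2-aminoethyl starting point. Both are modest and beyond the scatter, and both carry the carboxy group to a higher number. A step of similar size and direction, a 2.1-fold higher number from compound 2 to compound 4 (0.31 log units; beyond the scatter), is therefore expected in this assay.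

Compound 4 is expected to give about 16000 nM in this assay, with a range of 8000 nM to 32000 nM.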

Compound 4, half-maximal inhibitory concentration: 20100 nM
Compound 4: the middle estimate sits 1.3-fold (0.10 log units) below what was measured, within the range that was stated.
By their numbers in this assay, from the lowest: compounds 1 and 2 (each within the scatter of the next); then compounds 3 and 4 (each within the scatter of the next).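

Carboxy in place of hydroxymethyl on this saturated chain carbon now gives a modest rise with either drawn configuration: the earlier step to compound 3 is joined by a 2.6-fold higher number from compound 2 to compound 4 (0.41 log units; beyond the scatter), and the 2-aminoethyl comparison gives a 2.9-fold higher number from compound 1 to compound 4 (0.46 log units; beyond the scatter). New here is a direct comparison of configuration in this assay, a 1.2-fold higher number from compound 3 to compound 4 (0.08 log units; within the scatter), so this read-out does not separate the S and R forms as drawn. This comparison isolates the stereocentre alone: the fact that compounds 3 and 4 differ only in the configuration as drawn.

Open, as far as these compounds go, is how a methyl ester or a primary amide in place of the carboxy group, or a longer chain carrying it, would read in this assay. Also open, from the compounds shown here alone, is whether configuration would prove equally silent with the 1-(hydroxymethyl)ethyl group on the amide-type nitrogen.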